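Adding methoxy to the pyridine amide: compound 4 expected

The source may hold more compounds than are shown below. What is called first, only, known or untested is meant among the compounds shown, and "the series" means these compounds.

Compound 3 `O=C(Nc1nn[nH]n1)c1ccccn1` is the unsubstituted member of a small set of tetrazolyl amides examined in a functional assay on the whole organism for inhibition, with Rattus norvegicus as the target, at a dose of 10 mg/kg by the oral route; on this read-out lower numbers stand for a weaker effect and higher numbers for a stronger effect at the one dose given. Compound 3 gives 35%, the highest of the three numbers shown. Its nearest neighbour is compound 2 `O=C(Nc1nn[nH]n1)c1ncccc1Cl`, which in this assay gives 22%; the furthest is compound 1 `CCCCOc1cccc(C(=O)Nc2nn[nH]n2)n1`, which gives 8%.

The two steps that lead to compound 3 both remove a substituent from the ring carrying the carboxamide: a number 27 percentage points higher from compound 1 to compound 3 (beyond the scatter), and a number 13 percentage points higher from compound 2 to compound 3 (beyond the scatter). Both are modest but beyond the scatter, and both point the same way: the bare ring does better than either substituted one.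

Compound 4 `COc1ccnc(C(=O)Nc2nn[nH]n2)c1` reverses that direction by putting a group back on the ring. The change is methoxy in place of hydrogen on an aromatic carbon. Methoxy is a shorter alkoxy than the butoxy of compound 1 and sits at a different place, so the step of compound 1 bears on it only loosely, while the chloro step of compound 2 shows that even a small group at another place lowered the number. On that basis a modest decrease in this assay is expected, a number 13 percentage points lower from compound 3 to compound 4 (beyond the scatter).

Compound 4 is therefore estimated at 22% in this assay, with a range from 5% to 40%.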

Compound 4, a percentage reported as inhibition, in the whole organism at one dose (the size of the read-out at that dose, not a potency): 88%
Estimate against measurement, compound 4: 66 percentage points below; the measured number lies above the stated range.
By their numbers in this assay, from the lowest: compound 1; then compound 2; then compound 3; then compound 4.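

In this assay, methoxy in place of hydrogen on the aromatic carbon opposite the ring nitrogen gives a number 53 percentage points higher from compound 3 to compound 4 (beyond the scatter), the largest step in the set and the only one shown in which a group added to the bare ring raises the number. The earlier steps shown here pointed only the other way, with a number 27 percentage points higher from compound 1 to compound 3 (beyond the scatter) on loss of butoxy and a number 13 percentage points higher from compound 2 to compound 3 (beyond the scatter) on loss of chloro, so they showed the bare ring ahead of those two substituted rings but did not establish that a substituent lowers the number wherever it stands or whatever it is. Compound 4 shows that, at this place, a group of just 2 heavy atoms can lift the read-out well past the unsubstituted compound 3, although nothing available here accounts for the gain.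

The compounds shown leave open whether the gain belongs to methoxy itself or to this place on the ring. An ethoxy, a hydroxyl, an amine or a chloro on the same carbon, or methoxy moved to the carbons that carry butoxy or chloro in compound 1 and compound 2, would separate those two readings.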